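Dropping the Amide Arm of a Glutamate Receptor Modulator

The compounds below may be only part of what the source reports. "The series", "measured", "known", "first", "only" and "open" are said of these compounds alone.

Of the compounds shown here, two of a shared core have been measured. In an assay for positive allosteric modulation of metabotropic glutamate receptor 2 (Rattus norvegicus) (on this read-out higher numbers stand for an effect only at larger amounts of compound and lower numbers for an effect already at smaller amounts), compound 1 `COc1cc(C(=O)O)ccc1OC[C@H](C)COc1ccc(C(=O)CC(C)(C)C)c(O)c1C` gives 28 nM, and compound 2 `COc1ccc(C(=O)N(C)C)cc1OC[C@H](C)COc1ccc(C(=O)CC(C)(C)C)c(O)c1C` gives 5060 nM. Compound 2 therefore holds the higher of the two numbers, and its gap to compound 1 lies beyond the scatter. Compound 3 `COc1ccccc1OC[C@H](C)COc1ccc(C(=O)CC(C)(C)C)c(O)c1C` differs from compound 2 in one place: hydrogen in place of dimethylcarbamoyl on an aromatic carbon. For the measured compounds named here, no step between measured compounds is available, so the size of this step rests on judgement. Compound 3 is expected to give 800 nM in this assay, within 100 nM to 6000 nM. The expected step of a 6.3-fold lower number from compound 2 to compound 3 (0.80 log units; beyond the scatter) points toward a lower number, beyond the scatter.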

Compound 3, half-maximal effective concentration: "not active" (no number reported)
Nothing numeric was reported for compound 3, and the estimate cannot be compared.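

For the compounds shown here, compound 3 is reported as "not active" without a number, so no step from compound 2 to compound 3 can be read, and no supporting evidence bears on this result. From the compounds shown here alone, how large an effect removing dimethylcarbamoyl has remains open.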